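A Single Carbon Shorter: From Compound 3 to Compound 4

The source may hold more compounds than are shown below. What is called first, only, known or untested is meant among the compounds shown, and "the series" means these compounds.

Three benzamides sharing one core were measured in a functional assay on A-375 cells (Homo sapiens) for antiproliferative activity, read by CCK-8 assay, with a stated time of 72 h, tested at 8 uM; on this read-out higher numbers stand for a stronger effect at the one concentration tested and lower numbers for a weaker effect. Compound 1 `Nc1ccccc1NC(=O)c1ccc(CSC(=S)N2CCN(c3ccc(Cl)cc3)CC2)cc1` gave 29%, and compound 2 `Nc1ccccc1NC(=O)c1ccc(CSC(=S)N2CCc3cc([N+](=O)[O-])ccc32)cc1` gave 29.5%. Compound 3 `CCN(Cc1ccncc1)C(=S)SCc1ccc(C(=O)Nc2ccccc2N)cc1` gave 86.2%, the highest of the three numbers; its nearest neighbour is compound 2, whose number lies lower by a gap beyond the scatter, and compound 1 lies lower still.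

Compound 4 `CN(Cc1ccncc1)C(=S)SCc1ccc(C(=O)Nc2ccccc2N)cc1` has not yet been measured. It differs from compound 3 in one place: hydrogen in place of methyl on a saturated chain carbon bound to an amide-type nitrogen. Among the measured compounds shown here, no measured pair among the three compounds shows this change, so no step can be read for it directly; the ethyl to methyl change in the ethyl((pyridin-4-yl)methyl)amino group is the smallest alteration in the set. On that ground the expected step from compound 3 to compound 4 in this assay is small, most likely a slight decline or none beyond the scatter, a number 10.2 percentage points lower from compound 3 to compound 4 (beyond the scatter). Compound 4 is accordingly estimated at 76%, within a range from 52% to 92%.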

Compound 4, a percentage reported as inhibition, at one concentration (the size of the read-out at that concentration, not a potency): 86.1%
Estimate against measurement, compound 4: 10.1 percentage points below; measured number inside the range.
By their numbers in this assay, from the lowest: compounds 1 and 2 (each within the scatter of the next); then compounds 4 and 3 (each within the scatter of the next).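

In this assay, ethyl to methyl in the ethyl((pyridin-4-yl)methyl)amino group gives a number 0.1 percentage points lower from compound 3 to compound 4 (within the scatter). Among the compounds shown here, this is the first step in the set that can be read for a single change, and it shows that compound 3 and compound 4 cannot be told apart on this read-out when hydrogen takes the place of methyl on a saturated chain carbon bound to an amide-type nitrogen. No measurement at hand offers an explanation for this result.

From the compounds shown here alone, whether a longer chain such as propyl, or a cyclopropyl group or a hydrogen in place of the whole alkyl group, would give a similar number remains open. Compound 1 and compound 2 differ from these two compounds in more than one place, so steps involving them cannot be read.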